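Replacing the aryl group on the ring nitrogen of compound 3

The source may report more compounds than this note shows. Statements on the series, on what has been measured and on what is new or still open speak of the compounds shown alone.

Three thiazolidinone amides have been measured in a functional assay on HOS-TE85 cells (Homo sapiens) for inhibition, read by CCK-8 assay, with a stated time of 72 h; on this read-out higher numbers stand for weaker inhibition and lower numbers for stronger inhibition. Compound 1 `CC1SC(c2cccc(C(=O)NCCCCc3ccccc3)c2)N(c2ccc(C3CC3)cc2)C1=O` gives 191 nM, compound 2 `COc1ccc(C)cc1N1C(=O)CSC1c1cccc(C(=O)NCCCCc2ccccc2)c1` gives 300 nM, and compound 3 `COc1c(F)cccc1N1C(=O)CSC1c1cccc(C(=O)NCCCCc2ccccc2)c1` gives 26.2 nM, the lowest of the three numbers. Among the measured compounds shown here, the one single-point step, an 11-fold lower number from compound 2 to compound 3 (1.06 log units; beyond the scatter), shows that the aryl group on the ring nitrogen shifts the read-out strongly. Compound 4 `O=C(NCCCCc1ccccc1)c1cccc(C2SCC(=O)N2c2ccc(C3CC3)cc2)c1` differs from compound 3 by 4-cyclopropylphenyl in place of 3-fluoro-2-methoxyphenyl on an amide-type nitrogen in a ring. For the measured compounds named here, compound 1 carries this same 4-cyclopropylphenyl on its ring nitrogen but differs from compound 4 elsewhere in the shared core, so no measured step matches the change exactly. Compound 4 is expected to give roughly 200 nM, a weakening of a 7.6-fold higher number from compound 3 to compound 4 (0.88 log units; beyond the scatter) beyond the scatter, within a range of 60 nM to 650 nM.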

Compound 4, half-maximal inhibitory concentration: 217 nM
For compound 4 the middle estimate is 1.1-fold (0.04 log units) below the measured one, and the stated range covers the measured number.
By their numbers in this assay, from the lowest: compound 3; then compounds 1, 4 and 2 (each within the scatter of the next).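

In this assay, 4-cyclopropylphenyl on the ring nitrogen gives an 8.3-fold higher number from compound 3 to compound 4 (0.92 log units; beyond the scatter), so this replacement of 3-fluoro-2-methoxyphenyl also loses much of the low number. The 4-cyclopropylphenyl and 2-methoxy-5-methylphenyl groups cannot be told apart here, with a 1.4-fold lower number from compound 2 to compound 4 (0.14 log units; within the scatter), and hydrogen in place of methyl on the saturated ring carbon likewise gives a 1.1-fold higher number from compound 1 to compound 4 (0.06 log units; within the scatter). No independent measurement explains these results. Still open, from the compounds shown here alone, is how an aryl group carrying an amine or a carboxylic acid would read, and whether compound 3 depends more on its fluorine or its methoxy.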